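The compounds below may be only part of what the source reports. "The series", "measured", "known", "first", "only" and "open" are said of these compounds alone.

Compound 2 `CCCCOc1ccccc1C1CC(=O)c2ccccc2O1` in a functional assay on J774.A1 cells (Mus musculus) for inhibition, read by immunoassay, with a stated time of 12 h, tested at 30 uM (on this read-out higher numbers stand for more inhibition at the one concentration tested (going by the name of the read-out) and lower numbers for less inhibition), gives 42.5%, and compound 1 `O=C1CC(c2ccccc2OCc2ccc(F)cc2)Oc2ccccc21` gives 42.1%, the two numbers within the scatter of each other. Among the measured compounds shown here, the one measured step at this position, a number 0.4 percentage points higher from compound 1 to compound 2 (within the scatter), did not move the read-out beyond the scatter. Compound 3 `COCOc1ccccc1C1CC(=O)c2ccccc2O1` differs from compound 2 by methoxy in place of propyl on a saturated chain carbon bound to an oxygen on an aromatic ring. For the measured compounds named here, only that one step bears on the change, and it was small, so for compound 3 no step beyond the scatter is expected, a number 0.5 percentage points lower from compound 2 to compound 3 (within the scatter). Compound 3 is therefore estimated at 42%, with a range from 30% to 54%.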

Compound 3, a percentage reported as inhibition, at one concentration (the size of the read-out at that concentration, not a potency): 33.3%
Beside the measured number, compound 3's estimate is 8.7 percentage points above it, and the stated range covers the measured number.
By their numbers in this assay, from the lowest: compounds 3, 1 and 2 (each within the scatter of the next).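

Methoxy in place of propyl on a saturated chain carbon bound to an oxygen on an aromatic ring gives a number 9.2 percentage points lower from compound 2 to compound 3 (within the scatter) in this assay, and methoxy in place of 4-fluorophenyl gives a number 8.8 percentage points lower from compound 1 to compound 3 (within the scatter). The place therefore holds a chain with a hydrogen-bond acceptor as well as propyl and 4-fluorophenyl, with no step beyond the scatter. Nothing on hand bears on the reason for these steps.

Open, as far as these compounds go, is whether an amine or a carboxylic acid at this place would give a step beyond the scatter. From the compounds shown here alone, a chain longer than butoxy is equally open.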